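A few compounds are considered here, and "the series" means these few. Any claim that something is new, unique, unknown or untested is made for them only; others in the source may bear on it.

Working notes on the series. All three measured compounds share one core: compound 1 is `CC(=O)c1cc(-c2ccccc2)cc2cc(-c3ccccc3)[nH]c12`, compound 2 is `CC(=O)c1cc(-c2ccc(F)cc2)cc2cc(-c3ccccc3)[nH]c12`, and compound 3 is `CC(=O)c1cc(/C=C/c2ccccc2)cc2cc(-c3ccccc3)[nH]c12`. In a functional assay on MCF7 cells (Homo sapiens) for cytotoxicity, read by MTT assay, with a stated time of 2 days, tested at 0.1 uM (a lower number here means a stronger effect, a higher number a weaker effect of the compound at the concentration tested), compound 1 gives 99.3%, compound 2 gives 98.3%, and compound 3 gives 99.5%. Compound 3 carries the top number of the three, but this separates it from nothing: a number 0.2 percentage points higher from compound 1 to compound 3 (within the scatter), and a number 1.2 percentage points higher from compound 2 to compound 3 (within the scatter), so the three compounds are indistinguishable in this assay.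

Compound 4 is `CC(=O)c1cc(/C=C/c2ccc(F)cc2)cc2cc(-c3ccccc3)[nH]c12`. It differs from compound 3 by fluoro in place of hydrogen on an aromatic carbon. One measured step is of the same kind, the move from phenyl to 4-fluorophenyl, and there a number 1 percentage points lower from compound 1 to compound 2 (within the scatter). The swap of phenyl for 2-phenylethenyl likewise left the number where it was, a number 0.2 percentage points higher from compound 1 to compound 3 (within the scatter). Nothing in the series points to a fluoro on the outer ring moving the read-out, so no step beyond the scatter is expected in this assay. For compound 4 the expected step is a number 0.5 percentage points lower from compound 3 to compound 4 (within the scatter). Compound 4 is therefore estimated at 99% in this assay, within a range of 94% to 100%.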

Compound 4, a percentage reported as activity, at one concentration (the size of the read-out at that concentration, not a potency): 89.7%
Estimate against measurement, compound 4: 9.3 percentage points above; the whole stated range lies above it.
By their numbers in this assay, from the lowest: compounds 4, 2, 1 and 3 (each within the scatter of the next).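

In this assay, fluoro in place of hydrogen on the outer ring, para to a large group, stays within the scatter on the 2-phenylethenyl core too, with a number 9.8 percentage points lower from compound 3 to compound 4 (within the scatter). Among the compounds shown here, the longer replacements read the same way, with a number 8.6 percentage points lower from compound 2 to compound 4 (within the scatter) and a number 9.6 percentage points lower from compound 1 to compound 4 (within the scatter), so compound 4 is not separated from any earlier compound, although its steps are the largest so far. The fluoro change cannot be said to act differently on the two cores: the same change on two cores in this assay, a number 1 percentage points lower (within the scatter) from compound 1 to compound 2 and a number 9.8 percentage points lower (within the scatter) from compound 3 to compound 4, 8.8 percentage points apart, within the scatter of two such steps.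

On these data alone, whether an amine or a carboxylic acid at this place on the outer ring would give a step beyond the scatter remains open. As far as these compounds go, all four compounds are read at a single concentration, so a stronger or weaker effect of any one of them at that concentration, and any real order among them, also remain open.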